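The compounds below may be only part of what the source reports. "The series", "measured", "known", "first", "only" and "open" are said of these compounds alone.

Compound 1 `Cc1ccc(SCc2ccc(/C=C/C(=O)Nc3ccccc3N)cc2)cc1` was tested in a functional assay on HCT-116 cells (Homo sapiens) for inhibition, read by CCK-8 assay, with a stated time of 72 h, tested at 8 uM (on this read-out higher numbers stand for more inhibition of growth at the one concentration tested and lower numbers for less inhibition of growth), where compound 1 gives 4.93%, the lowest of the two numbers recorded. The other measured compound, compound 2 `Cc1ccc(SCc2ccc(C(=O)Nc3ccccc3N)cc2)cc1`, shares the same sulfur-linked core but lacks the two-carbon double bond that stretches the amide in compound 1; in this assay compound 2 gives 84%, which lies well beyond the scatter above compound 1. Among the measured compounds shown here, no pair of compounds has yet been compared that differs only in the group on the sulfur, so the effect of such a change is unknown here.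

Compound 3 `Nc1ccccc1NC(=O)/C=C/c1ccc(CSc2ccc(C(F)(F)F)cn2)cc1` keeps the stretched amide of compound 1 and changes only the aryl group on the sulfur: 5-(trifluoromethyl)pyridin-2-yl in place of 4-methylphenyl on a sulfur. For the measured compounds named here, with no comparable step measured, the expected change from compound 1 to compound 3 is small, estimated at a number 7.1 percentage points higher from compound 1 to compound 3 (within the scatter), lying within the scatter. Compound 3 is therefore expected to give about 12%, within a range from 0% to 40%.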

Compound 3, percent growth inhibition at one concentration: 14.9%
Compound 3: middle estimate off by 2.9 percentage points, on the low side; the measured number falls inside the stated range.
By their numbers in this assay, from the lowest: compounds 1 and 3 (each within the scatter of the next); then compound 2.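

In this assay, among the compounds shown here, this exchange of 4-methylphenyl for 5-(trifluoromethyl)pyridin-2-yl on a sulfur gives a number 10 percentage points higher from compound 1 to compound 3 (within the scatter) and is the first measured step at this position. The entering group has more heavy atoms than the one it replaces and brings a ring nitrogen and fluorine, yet the two compounds cannot be told apart on this read-out. On the core of compound 1, then, this one change leaves growth inhibition at the low level already seen, and nothing measured here offers an explanation for that.

As far as these compounds go, whether a different group on the sulfur, such as a 4-carboxyphenyl or a 4-aminophenyl ring, would separate from compound 1 remains open. Also open, from the compounds shown here alone, is what 5-(trifluoromethyl)pyridin-2-yl would do on the core of compound 2, which lacks the double bond.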